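Replacing a methylphenyl amide in a cytotoxic series

The compounds below may be only part of what the source reports. "The series", "measured", "known", "first", "only" and "open" are said of these compounds alone.

Of the compounds shown here, three sharing one core have been tested in a functional assay on WI-38 VA13 cells (Homo sapiens) for cytotoxicity; on this read-out lower numbers stand for an effect already at smaller amounts and higher numbers for an effect only at larger amounts of compound. Compound 1 `O=C(Nc1ccc2nc(NC(=O)C3CCCCC3)sc2c1)c1cccc(F)c1` gives 0.64 ug/mL. Compound 2 `Cc1ccc(C(=O)Nc2ccc3nc(NC(=O)C4CCCCC4)sc3c2)cc1` gives 5.1 ug/mL, and compound 3 `CCCC(C)C(=O)Nc1ccc2nc(NC(=O)C3CCCCC3)sc2c1` gives 0.14 ug/mL. Compound 2 therefore stands with the highest number of the three: the step of an 8.0-fold higher number from compound 1 to compound 2 (0.90 log units; beyond the scatter) is modest, and the step of a 36-fold lower number from compound 2 to compound 3 (1.56 log units; beyond the scatter) is large, so both neighbours act at smaller amounts than compound 2.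

Compound 4 `Cc1cc(C(=O)Nc2ccc3nc(NC(=O)C4CCCCC4)sc3c2)c(C)n1C` keeps the core of compound 2 and changes the group on the carbonyl carbon: 1,2,5-trimethyl-1H-pyrrol-3-yl in place of 4-methylphenyl on a carbonyl carbon. Going by the values given here, the steps that bear on this are an 8.0-fold higher number from compound 1 to compound 2 (0.90 log units; beyond the scatter) and a 36-fold lower number from compound 2 to compound 3 (1.56 log units; beyond the scatter), which show that every change away from 4-methylphenyl seen so far has lowered the number, once modestly and once by a large margin. Only a measurement can say where a 1,2,5-trimethyl-1H-pyrrol-3-yl group falls, but a modest step downward is expected, giving a 2.6-fold lower number from compound 2 to compound 4 (0.41 log units; beyond the scatter). Compound 4 is thus estimated at 2 ug/mL, within a range from 0.5 ug/mL to 8 ug/mL.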

Compound 4, half-maximal effective concentration: > 6.2 ug/mL
Compound 4: only a limit was reported; the forecaster's own chance of this, stated with the estimate: 5%; at least 3.1-fold (0.49 log units) between middle value and limit.
By their numbers in this assay, from the lowest: compound 3; then compound 1; then compound 2. At a limit, above all of these: compound 4.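

In this assay compound 4 gives only a limit, not a number: the limit of > 6.2 ug/mL in this assay, at which 1 of the 4 values shown sits.

So far, both changes away from 4-methylphenyl on this carbonyl carbon had lowered the number, but 1,2,5-trimethyl-1H-pyrrol-3-yl does not follow them: the data show only (an at least 1.2-fold higher number from compound 2 to compound 4 (0.08 log units; that floor lies within the scatter)) , and that floor does not separate compound 4 from compound 2. The separation from the other two compounds is clear (an at least 9.6-fold higher number from compound 1 to compound 4 (0.98 log units; beyond the scatter); an at least 44-fold higher number from compound 3 to compound 4 (1.64 log units; beyond the scatter)) , so the open-chain 1-methylbutyl group of compound 3 keeps the lowest number, and swapping one aromatic ring for another at this place can leave the number high, as in compound 4, or lower it, as in compound 1.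

From the compounds shown here alone, how far above its limit compound 4 really lies stays open. Also open, going by these compounds, are whether a pyrrole ring without the methyl groups would behave the same way, and how a longer chain or a chain carrying an amine would compare with 1-methylbutyl.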